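This account rests on a few compounds, and the source may have more. Where it says the series, first, only, none or still open, it means among the compounds named here.

In a functional assay on RPMI-8226 cells (Homo sapiens) for antiproliferative activity, read by radiometric assay, with a stated time of 72 h (a higher number here means a weaker inhibitor, a lower number a stronger inhibitor), compound 1 (`Cc1ccccc1Nc1ncnc2cc(NC(=O)CCCCCCC(=O)NO)sc12`) gives 1750 nM, compound 2 (`O=C(CCCCCCC(=O)Nc1cc2ncnc(Nc3ccc(Cl)cc3F)c2s1)NO`) gives 1900 nM and compound 3 (`COc1ccc(Nc2ncnc3cc(NC(=O)CCCCCCC(=O)NO)sc23)c(C)c1`) gives 1980 nM. Among the compounds with values here, compound 3 therefore stands level with the other two, and no measured step in this small set leaves the scatter. Compound 4 (`COc1ccc(Nc2ncnc3cc(NC(=O)CCCCCCC(=O)NO)sc23)cc1`) differs from compound 3 in one place: hydrogen in place of methyl on an aromatic carbon, ortho to a large group and meta to a methoxy group (hydrogen in place of methyl on an aromatic carbon).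

Within the data shown here, no measured step makes exactly this change, so the evidence is indirect. Adding the methoxy group gave a 1.1-fold higher number from compound 1 to compound 3 (0.05 log units; within the scatter). Exchanging the whole substituent on the nitrogen gave a 1.1-fold higher number from compound 1 to compound 2 (0.04 log units; within the scatter) and a 1.0-fold higher number from compound 2 to compound 3 (0.02 log units; within the scatter). All three steps lie within the scatter, although two of them altered that substituent far more than the loss of one methyl does. On that basis, no step beyond the scatter is expected in this assay, and no direction can be favoured with any confidence. The estimate means a 1.1-fold lower number from compound 3 to compound 4 (0.04 log units; within the scatter), an expected step that stays within the scatter. For compound 4 the expected value is 1800 nM, with an estimated range from 900 nM to 3500 nM.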

Compound 4, half-maximal inhibitory concentration: 1840 nM
Compound 4: middle estimate off by 1.0-fold (0.01 log units), on the low side, and the stated range covers the measured number.
By their numbers in this assay, from the lowest: compounds 1, 4, 2 and 3 (each within the scatter of the next).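

The loss of the methyl group, ortho to a large group and meta to a methoxy group, can now be read directly: in this assay it gives a 1.1-fold lower number from compound 3 to compound 4 (0.03 log units; within the scatter) and so shows that this position carries either methyl or hydrogen without a step beyond the scatter. Within the data shown here, the 4-methoxyphenyl group of compound 4 also stands level with the other two substituents on the nitrogen, with a 1.0-fold lower number from compound 2 to compound 4 (0.01 log units; within the scatter) in place of 4-chloro-2-fluorophenyl and a 1.1-fold higher number from compound 1 to compound 4 (0.02 log units; within the scatter) in place of 2-methylphenyl, so none of the substituents in these four compounds separates from the others, and no compound here goes against that. No measurement shown here offers an explanation for this result.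

The compounds shown leave open whether a carboxylic acid or a dimethylamino group at this same position, where only methyl and hydrogen appear, would produce a step beyond the scatter. They also leave open whether a longer chain in place of the chain shared by all four compounds would move the number more than any change to the substituent on the nitrogen has done.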